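The compounds below may be only part of what the source reports. "The series", "measured", "known", "first", "only" and "open" are said of these compounds alone.

Of the compounds shown here, two have been measured in an assay on isolated protein for inhibition of Long-chain-fatty-acid--CoA ligase 1 (Mus musculus), read by mass spectrometry, with a stated time of 90 min, in the presence of a further agent that is not named here; on this read-out lower numbers stand for stronger inhibition and higher numbers for weaker inhibition. Compound 1 `Cc1cccc(Cc2c(C(N)=O)c3cc(O[C@H]4CC[C@@H](C(=O)O)CC4)ccc3n2C)c1` gives 440 nM. Compound 2 `Cc1ccc(Cc2nc3cc(O[C@H]4CC[C@@H](C(=O)O)CC4)ccc3n2C)cc1` gives 80 nM, the lowest of the two numbers; its nearest neighbour is compound 1, and the gap between the two values lies beyond the usual scatter. Going by the values given here, no single-site step between measured compounds is available, so the effect of any one change on this read-out has not yet been isolated.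

Compound 3 `Cc1cccc(COc2nc3cc(O[C@H]4CC[C@@H](C(=O)O)CC4)ccc3n2C)c1` is the next compound, not yet measured. It differs from compound 2 in one place: (3-methylbenzyl)oxy in place of 4-methylbenzyl on an aromatic carbon. Among the compounds with values here, the data give no prior step of this kind. For compound 3 the expected step is a 1.9-fold higher number from compound 2 to compound 3 (0.27 log units; within the scatter), a modest shift toward a higher number, though a result within the scatter would not surprise. The estimate for compound 3 in this assay is 150 nM, with a range from 50 nM to 600 nM.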

Compound 3, half-maximal inhibitory concentration: 8100 nM
For compound 3 the middle estimate is 54-fold (1.73 log units) below the measured one, outside the stated range (above it).
By their numbers in this assay, from the lowest: compound 2; then compound 1; then compound 3.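

In this assay, this position, on an aromatic carbon between two ring nitrogen atoms, proves highly sensitive: (3-methylbenzyl)oxy in place of 4-methylbenzyl gives a 100-fold higher number from compound 2 to compound 3 (2.01 log units; beyond the scatter), so the two groups are far from interchangeable here. The step combines two differences, since the entering group carries an oxygen and a hydrogen-bond acceptor that the leaving group lacks, and its methyl is numbered differently on the benzyl, so this pair cannot assign the loss to either one. Nothing available accounts for the size of the step.

Open, from the compounds shown here alone, is how 3-methylbenzyl and (4-methylbenzyl)oxy would each read at this position, which would separate the oxygen from the placement of the methyl. Equally open, going by these compounds, is whether an amine as the linking atom in place of the oxygen would restore the lower numbers.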